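Swapping the dichlorophenyl sulfide for a fluorophenyl sulfide

This account rests on a few compounds, and the source may have more. Where it says the series, first, only, none or still open, it means among the compounds named here.

Of the compounds shown here, three built on one shared core have been measured in a functional assay on SW-620 cells (Homo sapiens) for inhibition, read by sulforhodamine B assay, with a stated time of 48 h; on this read-out lower numbers stand for stronger inhibition of growth and higher numbers for weaker inhibition of growth. Compound 1 `Nc1cc(N)c2nc(-c3ccccc3)c(NCc3ccc(F)cc3)nc2c1` gives 9550 nM. For compound 2 `COc1ccc(Sc2nc3cc(N)cc(N)c3nc2-c2ccccc2)cc1` the assay reports only a limit, < 100000 nM. Compound 3 `Nc1cc(N)c2nc(-c3ccccc3)c(Sc3ccc(Cl)c(Cl)c3)nc2c1` gives 83200 nM, the higher of the two readable numbers; its nearest neighbour is compound 1, and the step of an 8.7-fold higher number from compound 1 to compound 3 (0.94 log units; beyond the scatter). The step that the limit leaves unreadable from compound 2 to compound 3 cannot be read because of the limit of < 100000 nM in this assay, at which 1 of the 3 values shown sits.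

Compound 4 `Nc1cc(N)c2nc(-c3ccccc3)c(Sc3ccc(F)cc3)nc2c1` differs from compound 3 by 4-fluorophenyl in place of 3,4-dichlorophenyl on a sulfur. Within the data shown here, the only measured step that touches the aryl group on the sulfur, a step that the limit leaves unreadable from compound 2 to compound 3, is unreadable, and the step of an 8.7-fold higher number from compound 1 to compound 3 (0.94 log units; beyond the scatter) concerns a different group, so no measured step gives the size of this change. The step of a 1.2-fold lower number from compound 3 to compound 4 (0.08 log units; within the scatter) is therefore expected to lie within the scatter. Compound 4 is estimated at 70000 nM in this assay, with a range from 25000 nM to 200000 nM.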

Compound 4, concentration for total growth inhibition: 50100 nM
Compound 4: middle estimate off by 1.4-fold (0.15 log units), on the high side; the range from low to high includes it.
By their numbers in this assay, from the lowest: compound 1; then compounds 4 and 3 (each within the scatter of the next).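

In this assay, the aryl group on the sulfur now has its first readable step, a 1.7-fold lower number from compound 3 to compound 4 (0.22 log units; within the scatter), so this change from 3,4-dichlorophenyl to 4-fluorophenyl does not separate the two compounds. Replacing the (4-fluorobenzyl)amino group with a sulfide now reads twice, as an 8.7-fold higher number from compound 1 to compound 3 (0.94 log units; beyond the scatter) and as a 5.2-fold higher number from compound 1 to compound 4 (0.72 log units; beyond the scatter), so the higher number holds for both sulfides with a readable value. The steps from compound 2 cannot be read: the limit of < 100000 nM in this assay, at which 1 of the 4 values shown sits.

The compounds shown leave open whether an amine or a carboxylic acid on the aryl ring would move the number beyond the scatter. They also leave open whether a (4-fluorobenzyl)sulfanyl group would read with compound 1 or with the two sulfides.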